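Replacing a Benzyl Substituent with Butyl on the Shared Core

The source may report more compounds than this note shows. Statements on the series, on what has been measured and on what is new or still open speak of the compounds shown alone.

Measured so far:
Compound 1 `Nc1ccccc1NC(=O)/C=C/c1ccc(Cn2cnc3c(Nc4ccccc4)nc(Cl)nc32)cc1` gives 41.9% in a functional assay on HepG2 cells (Homo sapiens) for antiproliferative activity, read by CCK-8 assay, with a stated time of 72 h, tested at 8 uM; a higher number here means a stronger effect of the compound at the concentration tested, a lower number a weaker effect.
Compound 2 `Nc1ccccc1NC(=O)c1ccc(CNc2nc(Cl)nc3c2ncn3Cc2ccccc2)cc1` gives 5.32% in this assay.
Compound 3 `Nc1ccccc1NC(=O)c1ccc(Cn2cnc3c(NCc4ccccc4)nc(Cl)nc32)cc1` gives 62.8% in this assay.

Of the three, compound 2 stands weakest: both other compounds lie higher by more than the usual scatter. Compound 4 `CCCCn1cnc2c(NCc3ccc(C(=O)Nc4ccccc4N)cc3)nc(Cl)nc21` has not yet been measured. It differs from compound 2 in one place: propyl in place of phenyl on a saturated chain carbon bound to an aromatic nitrogen. Going by the values given here, no pair of measured compounds separates this change on its own, so no direct step is known. Compound 4 is therefore expected to stay close to compound 2, with a step of a number 4.7 percentage points higher from compound 2 to compound 4 (within the scatter) that would not exceed the scatter. Compound 4 is estimated at 10%, with a range from 0% to 28%.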

Compound 4, a percentage reported as inhibition, at one concentration (the size of the read-out at that concentration, not a potency): 19.6%
The estimate for compound 4 lay 9.6 percentage points below the measured number, and the stated range covers the measured number.
By their numbers in this assay, from the lowest: compound 2; then compound 4; then compound 1; then compound 3.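

Going by these compounds alone, at this place on a saturated chain carbon bound to an aromatic nitrogen, benzyl to butyl gives in this assay a step of a number 14.3 percentage points higher from compound 2 to compound 4 (beyond the scatter) and is the first direct reading of this change. The step shows that the phenyl ring is not needed here for the effect seen at the tested concentration, since the open propyl in its place loses nothing and gains modestly. Nothing shown accounts for the direction of this step.

From the compounds shown here alone, whether a shorter chain such as ethyl, a longer chain such as hexyl, or a butyl chain ending in an amine would raise the effect further remains open.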